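Compound 4: 4-hydroxyphenyl in place of 3-bromophenyl

This account rests on a few compounds, and the source may have more. Where it says the series, first, only, none or still open, it means among the compounds named here.

Measured so far in a functional assay on HL-60 cells (Homo sapiens) for cytotoxicity, read by MTT assay, with a stated time of 48 h; a lower number here means a stronger inhibitor, a higher number a weaker inhibitor:
Compound 1 `Fc1cccc(-c2nc(Nc3ccccc3)c3cc(F)ccc3n2)c1` gives 48300 nM
Compound 2 `Fc1cccc(-c2nc(Nc3ccc(Cl)cc3)c3cc(F)ccc3n2)c1` gives 45700 nM
Compound 3 `Fc1cccc(-c2nc(Nc3cccc(Br)c3)c3cc(F)ccc3n2)c1` gives > 50000 nM

The result for compound 3 is a limit and not a number: the limit of > 50000 nM in this assay, at which 1 of the 3 values shown sits. The unmeasured compound 4 `Oc1ccc(Nc2nc(-c3cccc(F)c3)nc3ccc(F)cc23)cc1` differs from compound 3 by one change, (4-hydroxyphenyl in place of 3-bromophenyl on a nitrogen on an aromatic ring), which is 4-hydroxyphenyl in place of 3-bromophenyl on a nitrogen on an aromatic ring.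

Going by the values given here, three measured steps concern the same group on that nitrogen. Chloro in place of hydrogen gave a 1.1-fold lower number from compound 1 to compound 2 (0.02 log units; within the scatter), bromo in place of hydrogen gave an at least 1.0-fold higher number from compound 1 to compound 3 (0.01 log units; that floor lies within the scatter), and 3-bromophenyl in place of 4-chlorophenyl gave an at least 1.0-fold higher number from compound 2 to compound 3 (0.03 log units; that floor lies within the scatter). Among the compounds with values here, none of these steps goes beyond the scatter, but none of the measured compounds carries a 4-hydroxyphenyl, so they guide the expectation only loosely. In this assay no clear step beyond the scatter is therefore expected, and the expected step is an at least 1.4-fold lower number from compound 3 to compound 4 (0.15 log units; that floor lies within the scatter). The estimate for compound 4 is 35000 nM, with an expected range from 10000 nM to 60000 nM.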

Compound 4, half-maximal inhibitory concentration: > 50000 nM
Compound 4: a limit, no number; the forecaster's own chance of this, stated with the estimate: 35%; middle value at least 1.4-fold (0.15 log units) away from the limit.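

In this assay compound 4 gives > 50000 nM, which is a limit and not a number, and it is the second compound shown to end at that limit: the limit of > 50000 nM in this assay, at which 2 of the 4 values shown sit.

Hydroxy in place of hydrogen gives an at least 1.0-fold higher number from compound 1 to compound 4 (0.01 log units; that floor lies within the scatter), and hydroxy in place of chloro gives an at least 1.0-fold higher number from compound 2 to compound 4 (0.03 log units; that floor lies within the scatter). So 4-hydroxyphenyl, the only group shown on that nitrogen that counts a hydrogen-bond donor and acceptor, brings no lower number in this assay, while the step between the two limits cannot be read.

The compounds shown leave open whether any group on that nitrogen can bring the number clearly down in this assay. An amine or a carboxylic acid on that phenyl ring would be one test of this, and a longer chain on the nitrogen would be another.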